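Swapping the Ketone Aryl Group: Compound 2 to Compound 3

The source may report more compounds than this note shows. Statements on the series, on what has been measured and on what is new or still open speak of the compounds shown alone.

Of the compounds shown here, two have been measured in a functional assay on A549 cells (Homo sapiens) for cytotoxicity, read by MTT assay, with a stated time of 48 h; a higher number here means a weaker inhibitor, a lower number a stronger inhibitor. Compound 1 `COc1cc(C(=O)C2Sc3nnc(-c4cc(OC)c(OC)c(OC)c4)n3NC2c2ccco2)cc(OC)c1OC` gives 48300 nM, and compound 2 `COc1cc(-c2nnc3n2NC(c2ccco2)C(C(=O)c2cccs2)S3)cc(OC)c1OC` gives 78700 nM. Among the measured compounds shown here, compound 2 holds the highest of the two numbers; its nearest neighbour is compound 1, and the single measured step, a 1.6-fold higher number from compound 1 to compound 2 (0.21 log units; within the scatter), lies within the scatter of repeated measurements. Compound 3 `COc1cc(-c2nnc3n2NC(c2ccco2)C(C(=O)c2ccc(Cl)cc2)S3)cc(OC)c1OC` has not yet been measured. It differs from compound 2 by 4-chlorophenyl in place of thiophen-2-yl on a carbonyl carbon. For the measured compounds named here, the one measured step that bears on this change is the earlier swap on the same carbonyl carbon, a 1.6-fold higher number from compound 1 to compound 2 (0.21 log units; within the scatter), which exchanged one aryl group for another without moving the number beyond the scatter. On that basis the step from compound 2 to compound 3 is expected to be small as well, with no direction that could be told from the scatter, and the estimated step is a 1.3-fold lower number from compound 2 to compound 3 (0.12 log units; within the scatter). Compound 3 is therefore expected to give about 60000 nM in this assay, with a likely range from 25000 nM to 150000 nM.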

Compound 3, half-maximal inhibitory concentration: 51400 nM
Beside the measured number, compound 3's estimate is 1.2-fold (0.07 log units) above it, within the range that was stated.
By their numbers in this assay, from the lowest: compounds 1, 3 and 2 (each within the scatter of the next).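

With compound 3, three different aromatic groups have been read on the carbonyl carbon in this assay, and the exchange of thiophen-2-yl for 4-chlorophenyl gives a 1.5-fold lower number from compound 2 to compound 3 (0.19 log units; within the scatter). The exchange of 3,4,5-trimethoxyphenyl for 4-chlorophenyl gives a 1.1-fold higher number from compound 1 to compound 3 (0.03 log units; within the scatter), so at this place, among these three compounds, a five-membered aromatic ring with a hetero atom and six-membered aromatic rings of carbon only, carrying either chlorine or methoxy groups, cannot be told apart by this read-out. Nothing available here bears on why these groups give numbers so close together.

As far as these compounds go, what a group of a different kind would do on this carbonyl carbon stays open: a saturated amine such as piperidine, a carboxylic acid or a longer alkyl chain might give a step beyond the scatter, or might not. The compounds shown also share the rest of the core, so they leave open whether a change elsewhere in the molecule would move the number in this assay further than any exchange at this place has done.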